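From Butyl to Trifluoromethylphenyl: Expected Cytotoxicity Step

A few compounds are considered here, and "the series" means these few. Any claim that something is new, unique, unknown or untested is made for them only; others in the source may bear on it.

Two compounds have been measured in an ADME assay on PANC-1 cells (Homo sapiens) for cytotoxicity, read by sulforhodamine B assay, with a stated time of 48 h, tested at 10 uM; on this read-out lower numbers stand for less inhibition and higher numbers for more inhibition at the one concentration tested (going by the name of the read-out):

Compound 1, `CCCCc1cn(C(c2ccccc2)c2cc3cc(Br)ccc3nc2OC)nn1`, gives 5.46%.
Compound 2, `COc1nc2ccc(Br)cc2cc1C(c1ccccc1)n1cc(-c2cccc(F)c2)nn1`, gives 15.5%.

Within the data shown here, compound 1 stands at the lower of the two numbers, with compound 2 the only neighbour; the step of a number 10 percentage points higher from compound 1 to compound 2 (within the scatter) lies within the scatter. Compound 3, `COc1nc2ccc(Br)cc2cc1C(c1ccccc1)n1cc(-c2ccccc2C(F)(F)F)nn1`, has not yet been measured. It differs from compound 1 by 2-(trifluoromethyl)phenyl in place of butyl on an aromatic carbon. Among the measured compounds shown here, the one measured step that bears on this change is the exchange of butyl for an aryl group in a number 10 percentage points higher from compound 1 to compound 2 (within the scatter), which stayed within the scatter. On that basis compound 3 is expected to land near compound 2, so that a number 6.5 percentage points higher from compound 1 to compound 3 (within the scatter) is estimated to remain within the scatter. The estimate for compound 3 in this assay is 12%, with a range from 0% to 28%.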

Compound 3, a percentage reported as inhibition, at one concentration (the size of the read-out at that concentration, not a potency): 11.4%
The estimate for compound 3 lay 0.6 percentage points above the measured number; low and high end bracket the measured number.
By their numbers in this assay, from the lowest: compounds 1, 3 and 2 (each within the scatter of the next).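

At the carbon of the five-membered ring that carries the varied group, 2-(trifluoromethyl)phenyl in place of butyl gives a number 5.9 percentage points higher from compound 1 to compound 3 (within the scatter) in this assay and so, like 3-fluorophenyl, leaves the read-out within the scatter. The position therefore accepts a second aryl group, one with more heavy atoms than butyl, without a step beyond the scatter. Among these compounds, the first comparison of one aryl group with another at this place, a number 4.1 percentage points lower from compound 2 to compound 3 (within the scatter), does not separate 3-fluorophenyl from 2-(trifluoromethyl)phenyl, and no supporting evidence explains this result.

As far as these compounds go, whether any group at this carbon can move the read-out beyond the scatter remains open, since these compounds carry only butyl and two fluorinated phenyl groups. An amine, a carboxylic acid or a longer chain there could still behave differently.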